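Replacing a Triazolyl Arm with a Dimethylaminopropyl Chain

A few compounds are considered here, and "the series" means these few. Any claim that something is new, unique, unknown or untested is made for them only; others in the source may bear on it.

Compound 1 `O=C1c2c[n+]([O-])c3ccccc3c2C(=O)c2c1c1ccccc1n2Cc1cn(CC(O)CO)nn1`: 1110 nM in a functional assay on MCF7 cells (Homo sapiens) for cytotoxicity, read by MTT assay, with a stated time of 72 h; on this read-out lower numbers stand for stronger inhibition and higher numbers for weaker inhibition
Compound 2 `CC1(C)OC[C@H](Cn2cc(Cn3c4c(c5ccccc53)C(=O)c3c[n+]([O-])c5ccccc5c3C4=O)nn2)O1`: 530 nM in this assay

Of the two measured compounds, compound 1 carries the highest number, so on this read-out it is the weaker of the pair. Among the compounds with values here, the one measured step is a 2.1-fold lower number from compound 1 to compound 2 (0.32 log units; beyond the scatter), where 2,2-dimethyl-1,3-dioxolan-4-yl replaces 1,2-dihydroxyethyl on a saturated chain carbon bound to an aromatic nitrogen.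

Compound 3 `CN(C)CCCCn1c2c(c3ccccc31)C(=O)c1c[n+]([O-])c3ccccc3c1C2=O` has not yet been measured. It differs from compound 1 in this way: 3-(dimethylamino)propyl in place of 1-(2,3-dihydroxypropyl)-1H-1,2,3-triazol-4-yl on a saturated chain carbon bound to an aromatic nitrogen. The whole triazolyl arm leaves and a short chain ending in a dimethylamino group enters at the same saturated chain carbon bound to an aromatic nitrogen. Within the data shown here, the step from compound 1 to compound 2 concerns a different change at that position and therefore bears on this one only loosely; it shows that altering the substituent on this chain carbon moved the number by a modest amount, and no measured step shows the effect of removing the ring entirely.

For compound 3 a modest improvement is expected, roughly a 1.9-fold lower number from compound 1 to compound 3 (0.27 log units; within the scatter), and the estimate in this assay for compound 3 is 600 nM, with a range from 150 nM to 2500 nM.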

Compound 3, half-maximal inhibitory concentration: 220 nM
The estimate for compound 3 lay 2.7-fold (0.44 log units) above the measured number; the range from low to high includes it.
By their numbers in this assay, from the lowest: compound 3; then compound 2; then compound 1.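

In this assay, the whole triazolyl arm can be given up at this position without loss: putting 3-(dimethylamino)propyl in place of 1-(2,3-dihydroxypropyl)-1H-1,2,3-triazol-4-yl gives a 5.0-fold lower number from compound 1 to compound 3 (0.70 log units; beyond the scatter). The earlier step changed only the far end of the arm and kept the triazole ring, whereas this one shows that a substituent with no ring, no hydrogen-bond donors and fewer heavy atoms is compatible with a lower number on the same core. The ring, the two hydroxyl groups and the dimethylamino group all change together in this single step, so it cannot be divided among them, and nothing measured here explains it.

On these data alone, what the dimethylamino group itself contributes, apart from the chain that carries it, remains open. A plain butyl chain with no amine at its end, a shorter or longer chain ending in the same dimethylamino group, or a morpholine in place of that group would each help to separate these contributions.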